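Trading the 2-chloroethyl of compound 3 for vinyl

The source may report more compounds than this note shows. Statements on the series, on what has been measured and on what is new or still open speak of the compounds shown alone.

Three amides sharing one core have been measured in a functional assay on KYSE-450 cells (Homo sapiens) for inhibition, read by MTT assay, with a stated time of 48 h; on this read-out higher numbers stand for weaker inhibition and lower numbers for stronger inhibition. Compound 1 `COc1ccc(CN(C(=O)C=C(C)C)c2cc(OC)c(OC)c(OC)c2)cc1O` carries a 2-methylprop-1-en-1-yl group on the carbonyl carbon, and in this assay compound 1 gives 280 nM. Compound 2 `COc1ccc(CN(C(=O)C(C)C)c2cc(OC)c(OC)c(OC)c2)cc1O` carries isopropyl there, and compound 2 gives 390 nM. Compound 3 `COc1ccc(CN(C(=O)CCCl)c2cc(OC)c(OC)c(OC)c2)cc1O` carries 2-chloroethyl and gives 110 nM, the lowest of the three numbers. The step of a 2.5-fold lower number from compound 1 to compound 3 (0.41 log units; beyond the scatter) and the step of a 3.5-fold lower number from compound 2 to compound 3 (0.55 log units; beyond the scatter) both lie beyond the scatter, while the step of a 1.4-fold higher number from compound 1 to compound 2 (0.14 log units; within the scatter) does not, so the 2-chloroethyl variant stands apart from the other two in this small set.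

Compound 4 `C=CC(=O)N(Cc1ccc(OC)c(O)c1)c1cc(OC)c(OC)c(OC)c1` differs from compound 3 in one place: vinyl in place of 2-chloroethyl on a carbonyl carbon. The measured steps that bear on this change are the two that lead into compound 3, a 2.5-fold lower number from compound 1 to compound 3 (0.41 log units; beyond the scatter) and a 3.5-fold lower number from compound 2 to compound 3 (0.55 log units; beyond the scatter); they show that a change of the group on the carbonyl carbon can move the number modestly, and that the unsaturated group of compound 1 did not come out worse than the saturated group of compound 2. For compound 4 the account therefore expects a number close to that of compound 3, with the step of a 1.1-fold lower number from compound 3 to compound 4 (0.04 log units; within the scatter) kept within or barely beyond the scatter. The estimate for compound 4 in this assay is 100 nM, expected to fall between 40 nM and 250 nM.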

Compound 4, half-maximal inhibitory concentration: 160 nM
For compound 4 the middle estimate is 1.6-fold (0.20 log units) below the measured one; the measured number falls inside the stated range.
By their numbers in this assay, from the lowest: compounds 3, 4, 1 and 2 (each within the scatter of the next, the first and the last beyond it).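

In this assay, the 2-chloroethyl group on the carbonyl carbon can give way to vinyl, losing the chlorine and gaining a double bond, without a change beyond the scatter (a 1.5-fold higher number from compound 3 to compound 4 (0.16 log units; within the scatter)), so among these amides the chlorine is not required for a number in this range. Vinyl also separates from isopropyl (a 2.4-fold lower number from compound 2 to compound 4 (0.39 log units; beyond the scatter)) but not from 2-methylprop-1-en-1-yl (a 1.8-fold lower number from compound 1 to compound 4 (0.24 log units; within the scatter)), which places compound 4 in a graded run of overlapping numbers rather than in a distinct group, since compound 4 lies within the scatter of both compound 3 and compound 1 although those two lie beyond the scatter of each other. Nothing available here explains why these groups read as they do.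

The compounds shown leave open how a plain ethyl group would read on the carbonyl carbon, a comparison that would set 2-chloroethyl and vinyl against a group with neither chlorine nor a double bond. They also leave open whether a longer chain such as 3-chloropropyl, or a 2-aminoethyl group, would keep the number in this range.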